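Replacing the oxolan-3-yl ether with methoxy in a quinazoline semicarbazone

The source may report more compounds than this note shows. Statements on the series, on what has been measured and on what is new or still open speak of the compounds shown alone.

Of the compounds shown here, two have been measured so far. Compound 1 `O=C(N/N=C/c1ccc(O)c(Br)c1)Nc1cc2c(Nc3ccc(F)c(Cl)c3)ncnc2cc1O[C@H]1CCOC1` gives 5230 nM in a functional assay on PC-3 cells (Homo sapiens) for cytotoxicity, read by MTT assay, with a stated time of 72 h (on this read-out lower numbers stand for stronger inhibition and higher numbers for weaker inhibition), and compound 2 `CCN(CC)c1ccc(/C=N/NC(=O)Nc2cc3c(Nc4ccc(F)c(Cl)c4)ncnc3cc2O[C@H]2CCOC2)c(O)c1` gives 4590 nM in this assay. Within the data shown here, the one step between them, a 1.1-fold lower number from compound 1 to compound 2 (0.06 log units; within the scatter), exchanges 4-(diethylamino)-2-hydroxyphenyl for 3-bromo-4-hydroxyphenyl on a carbon with a double bond to nitrogen. Compound 2 therefore holds the lowest of the two numbers, but its separation from compound 1 lies within the scatter, so the two are not distinguishable.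

Compound 3 `CCN(CC)c1ccc(/C=N/NC(=O)Nc2cc3c(Nc4ccc(F)c(Cl)c4)ncnc3cc2OC)c(O)c1` has not yet been measured. It differs from compound 2 by methyl in place of oxolan-3-yl on an oxygen on an aromatic ring. Among the measured compounds shown here, no measured step touches this oxygen on the aromatic ring; the only step on record alters a different part of the molecule and was itself within the scatter. There is thus no basis in the data for predicting a change in either direction, and the expectation is a step of about a 1.1-fold higher number from compound 2 to compound 3 (0.04 log units; within the scatter), not beyond the scatter. Compound 3 is accordingly estimated at 5000 nM, with a range from 2000 nM to 12500 nM.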

Compound 3, half-maximal inhibitory concentration: 34300 nM
Beside the measured number, compound 3's estimate is 6.9-fold (0.84 log units) below it; the whole stated range lies below it.
By their numbers in this assay, from the lowest: compounds 2 and 1 (each within the scatter of the next); then compound 3.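

Among these compounds, this is the first measured change on the oxygen on the aromatic ring, and in this assay the exchange of (oxolan-3-yl)oxy for methoxy gives a 7.5-fold higher number from compound 2 to compound 3 (0.87 log units; beyond the scatter), whereas the only earlier step, made elsewhere in the molecule, stayed within the scatter. The read-out is therefore sensitive to the group on this oxygen, at least with 4-(diethylamino)-2-hydroxyphenyl held constant, and here the oxolan-3-yl compound gives the lower number. The change removes a five-membered ring, a hydrogen-bond acceptor and a defined stereocentre together, and nothing available explains the rise in the number or assigns it to any one of these.

What remains open is which part of the oxolan-3-yl group matters, since only two groups on this oxygen are shown; a 2-methoxyethyl chain, a cyclopentyl ring or a morpholine-bearing propyl chain would help to separate the ring from its oxygen. Going by these compounds, it also remains open whether the step keeps its size when 3-bromo-4-hydroxyphenyl replaces 4-(diethylamino)-2-hydroxyphenyl on the carbon with a double bond to nitrogen.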